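The source may report more compounds than this note shows. Statements on the series, on what has been measured and on what is new or still open speak of the compounds shown alone.

Measured so far in a functional assay on A549 cells (Homo sapiens) for inhibition, read by CCK-8 assay, with a stated time of 72 h, tested at 8 uM; a lower number here means less inhibition of growth, a higher number more inhibition of growth at the concentration tested
- compound 1 `Nc1ccccc1NC(=O)/C=C/c1ccc(CSc2cccc(F)c2)cc1` gives 56.6% 
- compound 2 `Nc1ccccc1NC(=O)/C=C/c1ccc(CSCCc2ccccc2)cc1` gives 50.3% 

Compound 2 at 50.3% stands within the scatter of compound 1, so these two values give no ranking. Compound 3 `CC(C)(C)c1ccc(SCc2ccc(/C=C/C(=O)Nc3ccccc3N)cc2)cc1` carries 4-(tert-butyl)phenyl in place of phenethyl on a sulfur. Going by the values given here, one measured step bears on this change, as it involves the same sulfur and the same phenethyl group. With phenethyl in place of 3-fluorophenyl, it gives a number 6.3 percentage points lower from compound 1 to compound 2 (within the scatter) and so stays small. Among the compounds with values here, no measured compound carries 4-(tert-butyl)phenyl, so this single step is thin support. No step beyond the scatter is expected in this assay in either direction. The expected size is a number 3.7 percentage points higher from compound 2 to compound 3 (within the scatter) and no more. The estimate for compound 3 is 54% with an expected range of 40% to 68% for repeated measurements.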

Compound 3, percent growth inhibition at one concentration: 79.8%
Compound 3: middle estimate off by 25.8 percentage points, on the low side; the measured number lies above the stated range.
By their numbers in this assay, from the lowest: compounds 2 and 1 (each within the scatter of the next); then compound 3.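

In this assay, 4-(tert-butyl)phenyl in place of phenethyl on the sulfur gives a number 29.5 percentage points higher from compound 2 to compound 3 (beyond the scatter), and the same group in place of 3-fluorophenyl gives a number 23.2 percentage points higher from compound 1 to compound 3 (beyond the scatter). The group on this sulfur can therefore shift growth inhibition beyond the scatter, which the earlier pair did not show, and compound 3 stands clear of both other compounds. Nothing measured here accounts for this gain.

Compound 1 also carries a phenyl ring on the sulfur yet stays below compound 3, so an aromatic ring alone does not give the gain, but the role of the tert-butyl group itself remains unresolved. Also open, going by these compounds, is whether a smaller 4-methylphenyl, a 4-chlorophenyl, a cyclohexyl group or a group bearing an amine would hold this level.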